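Histamine H2 agonism: pyridin-2-yl in place of 3-fluorophenyl

The compounds below may be only part of what the source reports. "The series", "measured", "known", "first", "only" and "open" are said of these compounds alone.

Three measured compounds share one core: compound 1 `N=C(NCCCc1c[nH]cn1)NCCSC(c1ccccc1)c1ccccn1`, compound 2 `Cc1ccc(C(CC/N=C(\N)NCCCc2c[nH]cn2)c2ccccn2)cc1` and compound 3 `N=C(NCCCc1c[nH]cn1)NCCC(c1cccc(F)c1)c1ccccn1`. In a functional assay on cardiac atrium for agonist activity at histamine H2 receptor (Cavia porcellus) (on this read-out higher numbers stand for larger maximal responses and lower numbers for smaller maximal responses), compound 1 gives 1. In this assay compound 2 gives 1, and in this assay compound 3 gives 1. Compound 3 thus stands level with compound 1 and compound 2 at the digits recorded; its nearest neighbour on this read-out is compound 1 and its furthest is compound 2, and both gaps lie within the scatter of repeated measurements.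

Going by the values given here, no pair of measured compounds differs in a single place, so no measured single step is available for this series. Compound 4 `N=C(NCCCc1c[nH]cn1)NCCC(c1ccccn1)c1ccccn1` is not yet measured. Relative to compound 3 it carries pyridin-2-yl in place of 3-fluorophenyl on a saturated chain carbon bound to an aromatic carbon and a saturated chain carbon.

Every measured compound reaches the reference maximum, so no step beyond the scatter is expected from compound 3 to compound 4: no change at the digits printed from compound 3 to compound 4 (within the scatter). In this assay compound 4 is estimated at 1, in the range 0.9 to 1, because compound 3 gives 1.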

Compound 4, intrinsic activity: the largest response reached, as a fraction of the reference agonist's: 1
The estimate for compound 4 equals the measured number at the digits printed; low and high end bracket the measured number.
By their numbers in this assay, from the lowest: compounds 1, 2, 3 and 4 (each within the scatter of the next).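

In this assay the exchange of 3-fluorophenyl for pyridin-2-yl, on a saturated chain carbon bound to an aromatic carbon and a saturated chain carbon, shows no change at the digits printed from compound 3 to compound 4 (within the scatter) and gives the series its first single-place step. This position therefore accepts a second pyridin-2-yl, with one heavy atom fewer and one hydrogen-bond acceptor more than 3-fluorophenyl, and the maximal response stays level. Nothing available offers an explanation for this result.

Still open, on these data alone, is whether an amine, a carboxylic acid or a longer chain at this position would keep the maximal response in this assay within the scatter of compound 4. Also open, as far as these compounds go, is whether any read-out other than maximal response would separate compound 3 from compound 4, since on this one they stand level.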